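This account rests on a few compounds, and the source may have more. Where it says the series, first, only, none or still open, it means among the compounds named here.

Of the compounds shown here, three have numbers so far in a functional assay on DU-145 cells (Homo sapiens) for cytotoxicity, read by trypan blue exclusion, with a stated time of 96 h; on this read-out higher numbers stand for weaker inhibition and lower numbers for stronger inhibition. Compound 1 `COc1ccc(NS(=O)(=O)/C=C/c2c(F)c(F)c(F)c(F)c2F)cc1` gives 10000 nM. Compound 2 `COc1cc(OC)c(/C=C/S(=O)(=O)Nc2ccc(OC)c(OP(=O)(O)O)c2)c(OC)c1` gives 40 nM. Compound 3 `COC(=O)C(C)Nc1cc(NS(=O)(=O)/C=C/c2c(OC)cc(OC)cc2OC)ccc1OC` gives 100 nM, the second highest of the three numbers, far closer to compound 2 than to compound 1.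

Compound 4 `COc1cc(OC)c(/C=C/S(=O)(=O)Nc2ccc(OC)c(NC(C)(C)C(=O)O)c2)c(OC)c1` has not yet been measured in this assay. Its difference from compound 3 is 1-carboxy-1-methylethyl in place of 1-(methoxycarbonyl)ethyl on a nitrogen on an aromatic ring. The two hold the same atoms, joined differently, so 1-carboxy-1-methylethyl stands in place of 1-(methoxycarbonyl)ethyl on a nitrogen on an aromatic ring.

For the measured compounds named here, no measured step makes this exchange, so the evidence is indirect. Going by the values given here, the only step available is a 2.5-fold higher number from compound 2 to compound 3 (0.40 log units; beyond the scatter), a modest change beyond the scatter, which replaces one whole group on an aromatic carbon with another. Among the compounds with values here, compound 1 has no measured step to compound 3 and offers no guide. With that single step as the yardstick, a modest change of similar size is expected here, and a higher number is the more likely direction, though the data do not settle this. The expected step is a 2.5-fold higher number from compound 3 to compound 4 (0.40 log units; beyond the scatter). For compound 4 the estimated value is 250 nM, with an expected range from 60 nM to 1000 nM.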

Compound 4, half-maximal inhibitory concentration: 70 nM
Compound 4: middle estimate off by 3.6-fold (0.55 log units), on the high side; measured number inside the range.
By their numbers in this assay, from the lowest: compounds 2, 4 and 3 (each within the scatter of the next, the first and the last beyond it); then compound 1.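

On a nitrogen on an aromatic ring, 1-carboxy-1-methylethyl in place of 1-(methoxycarbonyl)ethyl gives a 1.4-fold lower number from compound 3 to compound 4 (0.15 log units; within the scatter) in this assay, so this rearrangement of the same atoms, which brings in a hydrogen-bond donor where the leaving group has none, does not move the read-out beyond the scatter. The comparison with the group of 5 heavy atoms in compound 2 gives a 1.8-fold higher number from compound 2 to compound 4 (0.24 log units; within the scatter), so although the earlier step set compound 3 beyond the scatter from compound 2, compound 4 cannot be separated from either of them in this assay. Nothing shown here explains why these groups read alike.

The compounds shown leave open how much each part of the exchange contributes, since methoxycarbonyl becoming carboxy and the change from 1-substituted ethyl to 1-methylethyl arrive together, and 1-carboxyethyl, which would part the two, is not among them. They also leave open how a plain amine or a longer chain on the same nitrogen would read in this assay.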